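Aryl substituent swap on the shared core: cytotoxicity notes

A few compounds are considered here, and "the series" means these few. Any claim that something is new, unique, unknown or untested is made for them only; others in the source may bear on it.

Measured compounds:
compound 1 `COc1nc(-c2ccc(C#N)cc2)ccc1[C@@H](c1ccccc1)[C@@](O)(CCN(C)C)c1cccc2ccccc12` — > 64 ug/mL
compound 2 `COc1nc(-c2cccc(Cl)c2)ccc1[C@@H](c1ccccc1)[C@@](O)(CCN(C)C)c1cccc2ccccc12` — "nd" (no result reported)
compound 3 `COc1nc(-c2cnsc2)ccc1[C@@H](c1ccccc1)[C@@](O)(CCN(C)C)c1cccc2ccccc12` — 28.8 ug/mL

In a toxicity assay on HeLa cells (Homo sapiens) for cytotoxicity (a higher number here means that more compound is tolerated, a lower number that less compound is tolerated), compound 1 gives > 64 ug/mL, which is a limit of the assay and not a number. Compound 2 has no result in this assay, entered as "nd" (no result reported). Compound 3 gives 28.8 ug/mL, a single number. Among the compounds with values here, the only step between measured compounds is an at least 2.2-fold lower number from compound 1 to compound 3 (0.34 log units; beyond the scatter), where 1,2-thiazol-4-yl stands in place of 4-cyanophenyl. Within the data shown here, compound 1 therefore stands at the upper end of what has been seen, at the limit of > 64 ug/mL in this assay, at which 1 of the 3 values shown sits; compound 3 is the only compound with a plain number.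

Compound 4 `COc1nc(-c2ccc(C(F)(F)F)cc2)ccc1[C@@H](c1ccccc1)[C@@](O)(CCN(C)C)c1cccc2ccccc12` is the next entry, differing from compound 1 by trifluoromethyl in place of cyano on an aromatic carbon. Among the measured compounds shown here, no measured step swaps trifluoromethyl for cyano on the same ring; the step from compound 1 to compound 3 changes the whole aryl group and bears on this only loosely, showing that a change at this position can move the number at least modestly. With compound 1 only a limit, the size of any step is uncertain. The expectation is a step no larger than modest, an at least 1.2-fold lower number from compound 1 to compound 4 (0.10 log units; that floor lies within the scatter), and compound 4 is estimated at 50 ug/mL, between 20 ug/mL and 120 ug/mL.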

Compound 4, half-maximal cytotoxic concentration: > 64 ug/mL
Compound 4 was reported as a limit; the forecaster's own chance of this, stated with the estimate: 40%; middle value at least 1.2-fold (0.10 log units) from the limit.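

In this assay, 4-(trifluoromethyl)phenyl joins 4-cyanophenyl at the top of the range seen so far, and this shared position is a limit of the assay, not a number: the limit of > 64 ug/mL in this assay, at which 2 of the 4 values shown sit.

Replacing 1,2-thiazol-4-yl with 4-(trifluoromethyl)phenyl gives an at least 2.2-fold higher number from compound 3 to compound 4 (0.34 log units; beyond the scatter), so compound 3 now stands apart from two substituted phenyl compounds rather than from one, though this rests on only these three compounds. Steps with a limit at both ends cannot be read, so the change from cyano to trifluoromethyl on this aromatic carbon has no readable size, and the two groups can be neither ranked nor called equal.

Open, from the compounds shown here alone, is whether an amine or a carboxylic acid on the phenyl ring would leave this assay at the limit. The alternative is that either group would bring the number down to the level of compound 3, at 28.8 ug/mL. Also open, going by these compounds, is whether the lower number of compound 3 belongs to the 1,2-thiazol-4-yl group itself or to the absence of a substituted phenyl ring, a question that an unsubstituted phenyl group at this position would help to separate.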